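The source may hold more compounds than are shown below. What is called first, only, known or untested is meant among the compounds shown, and "the series" means these compounds.

In an ADME assay on Huh-7 cells (Homo sapiens) for cytotoxicity (a lower number here means that less compound is tolerated, a higher number that more compound is tolerated), compound 2 `CN1CCN(CCNCc2cn(-c3ccc(F)cc3F)nc2Cc2ccccc2)CC1` gives > 20000 nM, which is a limit of the assay rather than a measured number. Compound 1 `Cc1ccccc1-c1nn(-c2ccc(F)cc2F)cc1CNCCN1CCCCC1` gives > 20000 nM, again only a limit. Compound 3 `Cc1ccccc1-c1nn(-c2cccc(Cl)c2)cc1CNCCN1CCN(C)CC1` gives 16000 nM, a real number that lies in the same region. Compound 2 therefore stands at the limit of > 20000 nM in this assay, at which 2 of the 3 values shown sit, and compound 3 sits not far from that point, so all three compounds are tolerated by the cells to a similar degree.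

Compound 4 `CN1CCN(CCNCc2cn(-c3ccc(F)cc3F)nc2-c2ccc(Cl)cc2)CC1` is compound 2 with a single change: 4-chlorophenyl in place of benzyl on an aromatic carbon. Compound 1 and compound 3 both carry an aromatic group on that same aromatic carbon of the five-membered aromatic ring, and their tolerability matches that of compound 2. Going by the values given here, no pair of measured compounds isolates this exact change, so its size can only be judged from the three values together.

The expected step is a number no higher from compound 2 to compound 4 (the limit leaves the size open), that is, little or no change beyond the usual scatter. Compound 4 is estimated at 20000 nM in this assay, with a range from 8000 nM to 50000 nM.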

Compound 4, half-maximal cytotoxic concentration: 19000 nM
The estimate for compound 4 lay 1.1-fold (0.02 log units) above the measured number; the range from low to high includes it.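

On this aromatic carbon, next to the ring nitrogen, 4-chlorophenyl in place of benzyl gives an at least 1.0-fold lower number from compound 2 to compound 4 (0.02 log units; that floor lies within the scatter) in this assay. Compound 4 thus adds a real number for a compound with this group on this carbon, and the two groups hold the same count of heavy atoms, so cells tolerate an aromatic ring with a chlorine on this carbon with no sign of a clear shift. How large the step really is stays unknown because compound 2 carries only a limit of the assay: the limit of > 20000 nM in this assay, at which 2 of the 4 values shown sit.

The compounds shown do not separate the effect of the chlorine from the effect of losing the benzyl carbon, which a plain phenyl on this carbon could do. They also leave open how cells would tolerate a group of another kind here, such as an amine or a carboxylic acid.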